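The compounds below may be only part of what the source reports. "The series", "measured", "known", "first", "only" and "open" are said of these compounds alone.

Compound 1 (`N=C(N)c1ccc2oc(-c3cccc(OCCCOc4ccccc4)c3)cc2c1`) gives 10300 nM in an ADME assay on L6 cells (Rattus norvegicus) for cytotoxicity, read by resazurin assay, with a stated time of 70 h; on this read-out lower numbers stand for stronger inhibition and higher numbers for weaker inhibition
Compound 2 (`N=C(N)c1ccc2oc(-c3cccc(OCCCCOc4ccccc4)c3)cc2c1`) gives 8100 nM in this assay

Compound 2 stands level with compound 1 on these two numbers, since the step of a 1.3-fold lower number from compound 1 to compound 2 (0.10 log units; within the scatter) is within the scatter. Compound 3 (`N=C(N)c1ccc2oc(-c3cccc(OCCCCCOc4ccccc4)c3)cc2c1`) differs from compound 2 in one place: phenoxymethyl in place of phenoxy on a saturated chain carbon, four bonds along the chain from an oxygen on an aromatic ring. For the measured compounds named here, the only measured step that bears on this change, a 1.3-fold lower number from compound 1 to compound 2 (0.10 log units; within the scatter), was within the scatter, so no step beyond the scatter is expected in this assay from compound 2 to compound 3. The estimate for compound 3 is 7000 nM with a range from 3500 nM to 14000 nM in this assay. That estimate means an expected step of a 1.2-fold lower number from compound 2 to compound 3 (0.06 log units; within the scatter), within the scatter.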

Compound 3, half-maximal inhibitory concentration: 3000 nM
For compound 3 the middle estimate is 2.3-fold (0.37 log units) above the measured one; measured number below the stated range.
By their numbers in this assay, from the lowest: compound 3; then compounds 2 and 1 (each within the scatter of the next).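

Phenoxymethyl in place of phenoxy on the chain now makes a real difference in this assay (a 2.7-fold lower number from compound 2 to compound 3 (0.43 log units; beyond the scatter)), whereas the same change made one step closer to the ring oxygen stayed within the scatter. Taken together, the two changes give 2-phenoxyethyl in place of phenoxy (a 3.4-fold lower number from compound 1 to compound 3 (0.54 log units; beyond the scatter)), so compound 3 has the lowest number of the series, meaning the strongest inhibition. No available measurement explains this shift. The compounds shown leave open whether a longer chain would lower the number further or raise it again. They also leave open whether an amine in place of the phenoxy group would keep this effect.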